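The compounds below may be only part of what the source reports. "The series", "measured", "known", "first", "only" and "open" are said of these compounds alone.

Among the measured compounds shown here, compound 2 `COCc1cccc(Cc2cnc(N)nc2N)c1` stands highest of the two numbers so far in a functional assay on L5178Y cells (Mus musculus) for inhibition (a lower number here means a less potent compound, a higher number a more potent compound, by a factor of ten per unit of this negative logarithm), at 3.65. Compound 1 `Nc1ncc(Cc2cc(CO)cc(CO)c2)c(N)n1` sits lower in this assay, at 2.49, a gap beyond the usual scatter. Compound 3 `CCCCOc1cccc(Cc2cnc(N)nc2N)c1` carries one change on the shared core: butoxy in place of methoxymethyl on an aromatic carbon. For the measured compounds named here, no measured pair shows this exchange, so the size of its step can only be guessed. A modest rise in this assay seems plausible, though a result within the scatter of compound 2 cannot be ruled out. For compound 3 the expected value is 3.9, in the range 3.2 to 4.6. The expected step is a number 0.25 log units higher from compound 2 to compound 3 (within the scatter).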

Compound 3, logarithm of the reciprocal of the active concentration, log(1/C): 4.99
The estimate for compound 3 lay 1.09 log units below the measured number, and the stated range ends below it.
By their numbers in this assay, from the lowest: compound 1; then compound 2; then compound 3.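

In this assay, butoxy in place of methoxymethyl on this aromatic carbon gives a number 1.34 log units higher from compound 2 to compound 3 (beyond the scatter). This position therefore responds strongly to the group it carries, although the two groups show the same hydrogen-bond donor and acceptor counts and differ in heavy atoms and in how they are built. Nothing available explains the size of this step.

On these data alone, whether a longer chain such as hexyloxy would extend this rise remains open. So does whether an amine or a carboxylic acid at this place would keep it.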